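The compounds below may be only part of what the source reports. "The series", "measured", "known", "first", "only" and "open" are said of these compounds alone.

Measured compounds:
- compound 1 `COc1cc(-c2cnn3cc(OC)c(C4CCCC4)nc23)ccn1` gives 32%
- compound 2 `COc1cc(-c2cnn3cc(OC)c(C4CCOC4)nc23)ccn1` gives 29%
- compound 3 `COc1cn2ncc(-c3ccnc(OC4CC4)c3)c2nc1-c1cnn(C)c1` gives 47%

In an ADME assay on microsomes from liver (Homo sapiens) for metabolic stability, with a stated time of 60 min, tested at 1 uM (on this read-out higher numbers stand for a more stable compound and lower numbers for a less stable compound), compound 1 stands second highest of the three numbers. Its nearest neighbour is compound 2, with a step of a number 3 percentage points lower from compound 1 to compound 2 (within the scatter), which lies within the scatter, so the two are not distinguishable on this read-out. Compound 3 lies furthest away, and the gap between compound 1 and compound 3 is beyond the scatter; since compound 3 differs from compound 1 in more than one place, no single step can be read from that pair.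

The new compound 4 `COc1cc(-c2cnn3cc(OC)c(N(C)C)nc23)ccn1` differs from compound 1 in one place: dimethylamino in place of cyclopentyl on an aromatic carbon.

Going by the values given here, only the step from compound 1 to compound 2 bears on this change, because a number 3 percentage points lower from compound 1 to compound 2 (within the scatter) also swaps the cyclopentyl group at the same aromatic carbon for another small group, and that step stayed within the scatter. Among the compounds with values here, no measured pair shows a dimethylamino group, so the expectation for compound 4 rests on that one step alone. Accordingly no step beyond the scatter is expected in this assay, and the estimate for compound 4 is 38%, with a range from 22% to 55%, corresponding to an expected step of a number 6 percentage points higher from compound 1 to compound 4 (within the scatter).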

Compound 4, percent of the compound remaining: 16%
Compound 4: middle estimate off by 22 percentage points, on the high side, outside the stated range (below it).
By their numbers in this assay, from the lowest: compound 4; then compounds 2 and 1 (each within the scatter of the next); then compound 3.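

In this assay, the place on the aromatic carbon ortho to a methoxy group proves sensitive to the group it carries: oxolan-3-yl for cyclopentyl had stayed within the scatter, but dimethylamino for cyclopentyl gives a number 16 percentage points lower from compound 1 to compound 4 (beyond the scatter) and is thus a change that can be told apart from the usual variation. The same holds against the oxygen-containing ring, where dimethylamino gives a number 13 percentage points lower from compound 2 to compound 4 (beyond the scatter) and the two compounds with a ring at this place, which cannot be told apart from each other, both stand above the compound without one. Nothing shown explains why the number falls with this change.

Dimethylamino differs from both ring groups in two ways at once, as it puts a nitrogen on the aromatic carbon and also removes the ring, so the compounds shown cannot say which of the two goes with the lower number. A pyrrolidin-1-yl group, which keeps the nitrogen within a ring, and an isopropyl group, an open carbon chain without nitrogen, would be the comparisons that separate these two differences at this place.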